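Compound 4: a shorter chain on the shared core

The source may report more compounds than this note shows. Statements on the series, on what has been measured and on what is new or still open speak of the compounds shown alone.

Three compounds have been tested so far in a functional assay on the whole organism (stomach) with Rattus norvegicus as the target; a higher number here means that more compound is needed for the effect, a lower number that less compound is needed:

compound 1 `Cc1ccc(=O)n(CC(=N)S)n1` gives a limit, > 100 mg/kg
compound 2 `Cc1ccc(=O)n(CCCCC(=N)S)n1` gives a limit, > 100 mg/kg
compound 3 `Cc1ccc(=O)n(C(C)CC(=N)S)n1` gives a limit, > 100 mg/kg

Compound 3 stands where its two companions stand: its result in this assay is a limit rather than a number, and the same is true of the other two values, as shown by the limit of > 100 mg/kg in this assay, at which 3 of the 3 values shown sit. Among the measured compounds shown here, no step between two measured compounds can be read from this set, since none of the three yields a number.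

Compound 4 `Cc1ccc(=O)n(CCC(=N)S)n1` differs from compound 3 by hydrogen in place of methyl on a saturated chain carbon bound to an aromatic nitrogen and a saturated chain carbon. For the measured compounds named here, with every measured value sitting at the limit, there is no measured step to lean on, and the step this estimate means, a step that the limit leaves unreadable from compound 3 to compound 4, is expected to be none beyond the scatter. Compound 4 is therefore expected to come out at 150 mg/kg in this assay, within a range from 40 mg/kg to 1000 mg/kg, and most likely it will again be reported only as a limit rather than as a number.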

Compound 4, dose for half-maximal effect: 43.2 mg/kg
Compound 4: middle estimate off by 3.5-fold (0.54 log units), on the high side, within the range that was stated.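

Compound 4 is the only compound shown that gives a number rather than a limit in this assay, so hydrogen in place of methyl on this saturated chain carbon now has a readable effect: an at least 2.3-fold lower number from compound 3 to compound 4 (0.36 log units; beyond the scatter). The length of the unbranched chain also separates the compounds, for a shorter and a longer chain alike: an at least 2.3-fold lower number from compound 1 to compound 4 (0.36 log units; beyond the scatter), and an at least 2.3-fold lower number from compound 2 to compound 4 (0.36 log units; beyond the scatter). All three steps are bounds rather than full sizes, and the other compounds remain limits: the limit of > 100 mg/kg in this assay, at which 3 of the 4 values shown sit.

On these data alone, how far compound 1, compound 2 and compound 3 actually lie from compound 4 stays open. As far as these compounds go, whether an ethyl group or a fluorine in place of that hydrogen would still give a number also stays open.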